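Dichlorophenyl in Place of Ethoxycarbonyl on a Fused Core

The compounds below may be only part of what the source reports. "The series", "measured", "known", "first", "only" and "open" are said of these compounds alone.

Of the compounds shown here, two have so far been measured in a functional assay on PC-12 cells (Rattus norvegicus) for cytotoxicity, read by MTT assay, with stated times of 3 h and 2 h, tested at 10 uM; a higher number here means a stronger effect of the compound at the concentration tested, a lower number a weaker effect. Compound 1 `O=C(CCCCC1CCSS1)NCc1cn(CCCOc2ccc3cc(-c4ccc(Br)cc4)c(=O)oc3c2)nn1` gives 63.3% in this assay. Among the compounds with values here, compound 2 `CCOC(=O)c1cc2ccc(OCCCCCn3cc(CNC(=O)CCCCC4CCSS4)nn3)cc2oc1=O` gives 38.3%, the lower of the two numbers; its only neighbour, compound 1, lies higher by a margin beyond the usual scatter. Compound 3 `O=C(CCCCC1CCSS1)NCc1cn(CCCCCOc2ccc3cc(-c4ccc(Cl)c(Cl)c4)c(=O)oc3c2)nn1` has not yet been measured. It differs from compound 2 in one place: 3,4-dichlorophenyl in place of ethoxycarbonyl on an aromatic carbon. At that position compound 1 likewise carries a substituted phenyl ring rather than an ethoxycarbonyl, and compound 1 gives 63.3% in this assay, so the step from compound 2 to compound 3 is expected to be upward and beyond the scatter, a number 19.7 percentage points higher from compound 2 to compound 3 (beyond the scatter). Compound 3 is estimated to give 58% in this assay, within a range from 42% to 74%.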

Compound 3, a percentage reported as activity, at one concentration (the size of the read-out at that concentration, not a potency): 59.4%
Compound 3: the middle estimate sits 1.4 percentage points below what was measured; measured number inside the range.
By their numbers in this assay, from the lowest: compound 2; then compounds 3 and 1 (each within the scatter of the next).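

In this assay, putting 3,4-dichlorophenyl in place of ethoxycarbonyl on this aromatic carbon gives a number 21.1 percentage points higher from compound 2 to compound 3 (beyond the scatter), with the rest of the molecule unchanged. Compound 1 and compound 2 differ in more than one place, so the gap between them could not be assigned to any single site, whereas this step ties a change in the read-out to this carbon alone. Nothing available explains why the read-out moves with this change.

Whether the step belongs to the aromatic ring itself or to its two chlorine atoms stays open, since an unsubstituted phenyl is not among the compounds shown. Also open, from the compounds shown here alone, is how a carboxylic acid would read at this carbon, and whether the same step would appear with a longer chain.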